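The source may report more compounds than this note shows. Statements on the series, on what has been measured and on what is new or still open speak of the compounds shown alone.

In a physicochemical assay for lipophilicity, at pH 7.4 (on this read-out lower numbers stand for lower lipophilicity and higher numbers for higher lipophilicity), compound 1 `CCS(=O)(=O)c1ccc(CN(CC(C)C)S(=O)(=O)c2ccc3c(c2)C(O)CC(C2CCOCC2)O3)nc1` gives 1.42 and compound 2 `CC(C)CN(c1cc2ccccc2s1)S(=O)(=O)c1ccc2c(c1)C(O)CC(C1CCOCC1)O2` gives 3.92 as the higher of the two numbers. Compound 3 `CC(C)CN(c1cccc(F)c1)S(=O)(=O)c1ccc2c(c1)C(O)CC(C1CCOCC1)O2` keeps the shared core and differs from compound 2 by one group, with 3-fluorophenyl in place of 1-benzothiophen-2-yl on a sulfonamide nitrogen as the counted change, 3-fluorophenyl in place of 1-benzothiophen-2-yl on a sulfonamide nitrogen. Among the compounds with values here, the one measured step on that nitrogen (a number 2.50 log units higher from compound 1 to compound 2 (beyond the scatter)) is large, but it involved a very different group, so it bears only loosely and a much smaller downward move is expected in this assay here. The estimated step (a number 0.52 log units lower from compound 2 to compound 3 (beyond the scatter)) is a moderate fall. For compound 3 the expected value is 3.4 (estimated range 3 to 3.8).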

Compound 3, distribution coefficient: 3.39
Compound 3: middle estimate off by 0.01 log units, on the high side; the range from low to high includes it.
By their numbers in this assay, from the lowest: compound 1; then compound 3; then compound 2.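

In this assay, 3-fluorophenyl in place of 1-benzothiophen-2-yl on the sulfonamide nitrogen gives a number 0.53 log units lower from compound 2 to compound 3 (beyond the scatter) and is a modest step, so two aromatic groups at this position now stand far from (5-(ethylsulfonyl)pyridin-2-yl)methyl. That group remains well apart, with a number 1.97 log units higher from compound 1 to compound 3 (beyond the scatter) as a large step, so most of the earlier gap survives the exchange. As far as these compounds go, whether an amine or a carboxylic acid on the phenyl ring, or a plain benzyl group, would fall nearer compound 1 stays open. Nothing available explains these shifts.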